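The compounds below may be only part of what the source reports. "The series", "measured", "known", "first", "only" and "open" are said of these compounds alone.

Working notes, cytotoxicity series. Among the compounds with values here, compound 3 `O=C(NNC(=S)Nc1ccccc1F)c1cc([N+](=O)[O-])c[nH]1` stands highest of the three numbers so far in an ADME assay on Vero cells (Chlorocebus sabaeus) for cytotoxicity, read by MTT assay, with a stated time of 72 h (a higher number here means a weaker inhibitor, a lower number a stronger inhibitor), at 471000 nM. Its nearest neighbour is compound 2 `O=C(NNC(=S)Nc1ccc(F)cc1)c1cc([N+](=O)[O-])c[nH]1`, which in this assay gives 331000 nM; the step of a 1.4-fold higher number from compound 2 to compound 3 (0.15 log units; within the scatter) lies within the scatter. Compound 1 `Cn1cc([N+](=O)[O-])cc1C(=O)NNC(=S)Nc1ccc(Cl)cc1` gives 210000 nM in this assay, a gap from compound 3 that does exceed the scatter. Compound 4 `O=C(NNC(=S)NC1CCCCC1)c1cc([N+](=O)[O-])c[nH]1` is the next compound; the change from compound 3 is cyclohexyl in place of 2-fluorophenyl on an amide-type nitrogen. Within the data shown here, no measured step exchanges an aromatic ring for a non-aromatic one; the only step on this nitrogen, a 1.4-fold higher number from compound 2 to compound 3 (0.15 log units; within the scatter), was small. The expected step of a 1.2-fold lower number from compound 3 to compound 4 (0.07 log units; within the scatter) is therefore none beyond the scatter, and compound 4 is estimated at 400000 nM with a range of 180000 nM to 900000 nM in this assay.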

Compound 4, half-maximal inhibitory concentration: 204000 nM
Compound 4: the middle estimate sits 2.0-fold (0.29 log units) above what was measured, within the range that was stated.
By their numbers in this assay, from the lowest: compounds 4, 1, 2 and 3 (each within the scatter of the next, the first and the last beyond it).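

Within the data shown here, on the amide-type nitrogen, the first step beyond the scatter in this assay comes with cyclohexyl in place of 2-fluorophenyl (a 2.3-fold lower number from compound 3 to compound 4 (0.36 log units; beyond the scatter)). With cyclohexyl in place of 4-fluorophenyl, the step stays within the scatter (a 1.6-fold lower number from compound 2 to compound 4 (0.21 log units; within the scatter)), so exchanging an aromatic ring for a non-aromatic one does not read the same from both fluorophenyl compounds. Nothing at hand accounts for this result.

Open, going by these compounds, is how a benzyl group or a longer alkyl chain on this nitrogen would read against cyclohexyl. Also open, on these data alone, is whether cyclohexyl gives a similar step on the core of compound 1.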